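The source may report more compounds than this note shows. Statements on the series, on what has been measured and on what is new or still open speak of the compounds shown alone.

Three measured compounds share one core and differ at a single aromatic carbon of it. Compound 1 `CC(C)c1ccc(Cc2sc3c(c2C(=O)N[C@@H](C)c2ccc(C(=O)O)cc2)CCOC3)cc1` gives 2.7 nM in a functional assay on CHO/Galpha16 cells for antagonist activity at prostaglandin E2 receptor EP4 subtype (Homo sapiens), read by calcium flux, with a stated time of 15 min; on this read-out lower numbers stand for stronger inhibition and higher numbers for weaker inhibition. Compound 2 `COc1cccc(C#Cc2sc3c(c2C(=O)N[C@@H](C)c2ccc(C(=O)O)cc2)CCOC3)c1` gives 12.4 nM in this assay. Compound 3 `C[C@H](NC(=O)c1c(C#Cc2ccc(F)cc2)sc2c1CCOC2)c1ccc(C(=O)O)cc1` gives 15.8 nM in this assay, the highest of the three numbers; against compound 2 it lies within the scatter, against compound 1 beyond it.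

Compound 4 `COc1ccc(Cc2sc3c(c2C(=O)N[C@@H](C)c2ccc(C(=O)O)cc2)CCOC3)cc1` is not yet measured. Its change from compound 3 is 4-methoxybenzyl in place of 2-(4-fluorophenyl)ethynyl on an aromatic carbon. The step that bears on it most directly is a 5.9-fold higher number from compound 1 to compound 3 (0.77 log units; beyond the scatter), which runs in the opposite direction to the change here; a 4.6-fold higher number from compound 1 to compound 2 (0.66 log units; beyond the scatter) is a second step of the same kind, and a 1.3-fold higher number from compound 2 to compound 3 (0.11 log units; within the scatter) shows that the two ethynyl variants do not separate. Among the compounds with values here, no measured pair compares 4-methoxybenzyl with 4-isopropylbenzyl, so the size of the expected return rests on compound 1 alone and carries that uncertainty. A lower number is therefore expected for compound 4, by about a 3.5-fold lower number from compound 3 to compound 4 (0.55 log units; beyond the scatter). The estimate for compound 4 in this assay is 4.5 nM, with a range from 1.5 nM to 14 nM.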

Compound 4, half-maximal inhibitory concentration: 2.1 nM
Beside the measured number, compound 4's estimate is 2.1-fold (0.33 log units) above it, within the range that was stated.
By their numbers in this assay, from the lowest: compounds 4 and 1 (each within the scatter of the next); then compounds 2 and 3 (each within the scatter of the next).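

In this assay, at the aromatic carbon next to the ring sulfur, 4-methoxybenzyl in place of the ethynyl groups gives a 7.5-fold lower number from compound 3 to compound 4 (0.88 log units; beyond the scatter) and a 5.9-fold lower number from compound 2 to compound 4 (0.77 log units; beyond the scatter), so the separation between benzyl and ethynyl groups at this position no longer rests on compound 1 alone. Methoxy in place of isopropyl gives a 1.3-fold lower number from compound 1 to compound 4 (0.11 log units; within the scatter), so these two benzyl groups do not separate here, and neither do the two ethynyl groups. Nothing shown gives a reason for these steps.

The compounds shown leave open whether an amine or a nitrile in place of the methoxy would keep the number in the same range. They also leave open how a longer chain between the aromatic ring and the shared core would read.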